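This account rests on a few compounds, and the source may have more. Where it says the series, first, only, none or still open, it means among the compounds named here.

In an ADME assay on microsomes from liver (Mus musculus) for metabolic stability, read by LC-MS, with a stated time of 10 min, tested at 0.5 uM (on this read-out lower numbers stand for a less stable compound and higher numbers for a more stable compound), three compounds have been measured so far. Compound 1 `c1ccc2c(c1)CN[C@@H](CN(CC1CCNCC1)[C@H]1CCCc3cccnc31)C2` gives 13%, compound 3 `CC(C)N1CCN(CCCN(C[C@H]2Cc3ccccc3CN2)[C@H]2CCCc3cccnc32)CC1` gives 58%, and compound 2 `c1ccc2c(c1)CN[C@H](CN(CCCN1CCNCC1)[C@H]1CCCc3cccnc31)C2` gives 88%. Compound 2 therefore stands highest of the three, with a gap beyond the scatter to each of the other two.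

Compound 4 `c1cnc2c(c1)CCC[C@@H]2N(CCCN1CCNCC1)Cc1cc2ccccc2cn1` has not yet been measured. It differs from compound 2 in a single group: isoquinolin-3-yl in place of 1,2,3,4-tetrahydroisoquinolin-3-yl on a saturated chain carbon bound to an amine nitrogen. In words, isoquinolin-3-yl stands in place of 1,2,3,4-tetrahydroisoquinolin-3-yl on a saturated chain carbon bound to an amine nitrogen.

Among the compounds with values here, only one measured step changes a single place, a number 45 percentage points higher from compound 1 to compound 3 (beyond the scatter), and it is large. Within the data shown here, it swaps piperidin-4-yl for 2-(4-isopropylpiperazin-1-yl)ethyl, a different exchange from the one in compound 4. It shows that one exchange in this series can move the number a long way, but it gives no direct guide to the size or direction of this step. Among the measured compounds shown here, no measured compound carries isoquinolin-3-yl.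

Compound 2, at 88%, has more room to fall than to rise, so a moderate drop is expected, though with wide uncertainty. The expected step is a number 18 percentage points lower from compound 2 to compound 4 (beyond the scatter). The estimated value for compound 4 is 70%, within an expected range of 40% to 93%.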

Compound 4, percent of the compound remaining: 74%
Estimate against measurement, compound 4: 4 percentage points below; the measured number falls inside the stated range.
By their numbers in this assay, from the lowest: compound 1; then compound 3; then compound 4; then compound 2.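

Within the data shown here, the exchange of 1,2,3,4-tetrahydroisoquinolin-3-yl for isoquinolin-3-yl, on a saturated chain carbon bound to an amine nitrogen, gives the first reading at this position: in this assay it produces a number 14 percentage points lower from compound 2 to compound 4 (beyond the scatter), a real but modest loss of stability. The count of heavy atoms stays the same, yet a non-aromatic ring becomes an aromatic one, and the hydrogen-bond donor and the defined stereocentre of the leaving group are both gone, so this position accepts quite a large change in the group at a modest cost. Nothing here ties the step to a property of either group.

The compounds shown leave open which of the three differences (the aromatic ring, the lost donor or the lost stereocentre) goes with the lower number, as this single exchange changes all of them at once. A tetrahydroisoquinoline carrying a methyl group on its ring nitrogen, or a plain phenyl group at this place, could begin to pull these differences apart.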